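Methyl position on the triazole aryl and GES1 tolerance

The source may hold more compounds than are shown below. What is called first, only, known or untested is meant among the compounds shown, and "the series" means these compounds.

Measured compounds:
compound 1, `Cc1cccc(-n2cc(-c3ccccc3NS(=O)(=O)c3c[nH]c(=O)[nH]c3=O)nn2)c1`, 23700 nM
compound 2, `Cc1ccc(-n2cc(-c3ccccc3NS(=O)(=O)c3c[nH]c(=O)[nH]c3=O)nn2)cc1`, 32400 nM
compound 3, `Cc1cccc(-n2cc(-c3cccc(NS(=O)(=O)c4c[nH]c(=O)[nH]c4=O)c3)nn2)c1`, 18500 nM

The three measured compounds were tested in an ADME assay on GES1 cells (Homo sapiens) for cytotoxicity, read by MTT assay, with a stated time of 24 h; a higher number here means that more compound is tolerated, a lower number that less compound is tolerated. Compound 1 gives 23700 nM, compound 2 gives 32400 nM, and compound 3 gives 18500 nM. All three numbers lie within the scatter of one another, so none of them can be set apart from the others.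

Compound 1 and compound 2 differ in one place: 4-methylphenyl in place of 3-methylphenyl on an aromatic nitrogen This change made a 1.4-fold higher number from compound 1 to compound 2 (0.14 log units; within the scatter). Compound 3 differs from compound 1 in its core; the difference between the two cores is not broken down here.

Compound 4, `Cc1ccc(-n2cc(-c3cccc(NS(=O)(=O)c4c[nH]c(=O)[nH]c4=O)c3)nn2)cc1`, has not yet been measured in this assay. It stands to compound 3 as compound 2 stands to compound 1: 4-methylphenyl in place of 3-methylphenyl on an aromatic nitrogen The place lines of the two changes are the same word for word, so this is the same change, made on the core of compound 3 rather than that of compound 1.

Because the same change gave a 1.4-fold higher number from compound 1 to compound 2 (0.14 log units; within the scatter), compound 4 is expected to show a step of similar size, a 1.4-fold higher number from compound 3 to compound 4 (0.13 log units; within the scatter), which stays within the scatter. Compound 4 is therefore estimated at 25000 nM, with a likely range from 12000 nM to 50000 nM.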

Compound 4, half-maximal cytotoxic concentration: 15800 nM
Beside the measured number, compound 4's estimate is 1.6-fold (0.20 log units) above it; the measured number falls inside the stated range.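

In this assay, putting 4-methylphenyl in place of 3-methylphenyl on the core of compound 3 gave a 1.2-fold lower number from compound 3 to compound 4 (0.07 log units; within the scatter). Set beside the same change on the core of compound 1, the two steps point in opposite directions on paper, yet the gap between them is no larger than two such steps can show by chance: the same change on two cores in this assay, a 1.4-fold higher number (0.14 log units; within the scatter) from compound 1 to compound 2 and a 1.2-fold lower number (0.07 log units; within the scatter) from compound 3 to compound 4, 1.6-fold (0.20 log units) apart, within the scatter of two such steps. This shows that on both cores the change stays within the scatter, so in this small series it carries from one core to the other as a change with no readable effect on tolerance, but it does not show a reversal of direction between the cores, nor that the two methylphenyl groups are truly equivalent, since a small real difference could lie hidden in the scatter, and two cores are too few to speak for the series as a whole.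

The compounds shown vary the aryl group on the triazole only by the place of a single methyl, so they leave open whether a carboxylic acid, an amine or a longer chain such as butyl on that phenyl ring would give a step beyond the scatter. They also leave open whether such a step would then carry from one core to the other.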